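This account rests on a few compounds, and the source may have more. Where it says the series, first, only, none or still open, it means among the compounds named here.

Compound 1 `O=C(O)c1cc(N2C(=O)C3=C(CCCC3)C2=O)ccc1Cl`: > 100000 nM
Compound 2 `CC(C)OC(=O)c1cc(N2C(=O)C3=C(CCCC3)C2=O)ccc1Cl`: 1000 nM
Compound 3 `CCCCOC(=O)c1cc(N2C(=O)C3=C(CCCC3)C2=O)ccc1Cl`: 3550 nM

All three were tested in a functional assay on the whole organism with Scenedesmus acutus as the target; a lower number here means a stronger inhibitor, a higher number a weaker inhibitor. The value of compound 1 is a limit of the assay, not a number. Of the two true numbers, the higher belongs to compound 3, at 3550 nM; the step to it is a 3.6-fold higher number from compound 2 to compound 3 (0.55 log units; beyond the scatter).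

Compound 4 `CCC(C)OC(=O)c1cc(N2C(=O)C3=C(CCCC3)C2=O)ccc1Cl` keeps the shared core and differs from compound 3 only in the ester: sec-butyl in place of butyl on an oxygen next to a carbonyl group. This places sec-butyl in place of butyl on an oxygen next to a carbonyl group. The closest guide is the modest step of a 3.6-fold higher number from compound 2 to compound 3 (0.55 log units; beyond the scatter), since sec-butyl is branched like the isopropyl of compound 2. The large steps of an at least 100-fold lower number from compound 1 to compound 2 (2.00 log units; beyond the scatter) and an at least 28-fold lower number from compound 1 to compound 3 (1.44 log units; beyond the scatter) both start from a limit and say little about exchanging one ester group for another. A modest move toward compound 2 is therefore expected in this assay, and the expected step is a 2.2-fold lower number from compound 3 to compound 4 (0.35 log units; beyond the scatter). The estimate for compound 4 is 1600 nM, with an expected range of 700 nM to 3800 nM.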

Compound 4, half-maximal inhibitory concentration: 794 nM
For compound 4 the middle estimate is 2.0-fold (0.30 log units) above the measured one; the range from low to high includes it.
By their numbers in this assay, from the lowest: compounds 4 and 2 (each within the scatter of the next); then compound 3. At a limit, above all of these: compound 1.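

In this assay, sec-butyl in place of butyl gives a 4.5-fold lower number from compound 3 to compound 4 (0.65 log units; beyond the scatter); the two compounds have the same atoms, joined differently, so the arrangement of the ester group alone moves the number beyond the scatter. The added methyl that distinguishes sec-butyl from isopropyl gives a 1.3-fold lower number from compound 2 to compound 4 (0.10 log units; within the scatter), so the two branched esters cannot be told apart here, while the unbranched butyl ester of compound 3 stands apart from both. The step of an at least 120-fold lower number from compound 1 to compound 4 (2.10 log units; beyond the scatter) starts from a limit and therefore gives only a bound on the gain from the ester: the limit of > 100000 nM in this assay, at which 1 of the 4 values shown sits.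

The contrast between branched and unbranched esters rests on compound 3 alone. As far as these compounds go, whether a tert-butyl ester, a longer chain or an amide at this place would keep the number near that of compound 4 remains open.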